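The source may hold more compounds than are shown below. What is called first, only, known or untested is meant among the compounds shown, and "the series" means these compounds.

In a functional assay on MCF7 cells (Homo sapiens) for inhibition, read by MTT assay, with a stated time of 48 h, tested at 2 uM (a lower number here means less inhibition, a higher number more inhibition at the concentration tested (going by the name of the read-out)), the measured compounds stand as follows:
Compound 1 `Cc1noc(C)c1-c1ccc2c(c1)C(c1ccccc1)N(Cc1nnc(-c3ccccc3)o1)C(=O)N2C` gives 34.1%.
Compound 2 `Cc1nc(-c2ccccc2)sc1CN1C(=O)N(C)c2ccc(-c3c(C)noc3C)cc2C1c1ccccc1` gives 35.1%.
Compound 3 `Cc1noc(C)c1-c1ccc2c(c1)C(c1ccccc1)N(Cc1nc(-c3ccccc3)cs1)C(=O)N2C` gives 29.1%.

Set against the other two, compound 3 differs by a number 5 percentage points lower from compound 1 to compound 3 (within the scatter) and by a number 6 percentage points lower from compound 2 to compound 3 (within the scatter), so the three numbers stand together. Compound 4 `Cc1noc(C)c1-c1ccc2c(c1)C(c1ccccc1)N(Cc1csc(-c3ccc(F)cc3)n1)C(=O)N2C` has not yet been measured; it differs from compound 3 in one place: 2-(4-fluorophenyl)-1,3-thiazol-4-yl in place of 4-phenyl-1,3-thiazol-2-yl on a saturated chain carbon bound to an amide-type nitrogen in a ring. Every measured step here is a swap of the aromatic group at that same place, and each of them, a number 1 percentage points higher from compound 1 to compound 2 (within the scatter), a number 5 percentage points lower from compound 1 to compound 3 (within the scatter) and a number 6 percentage points lower from compound 2 to compound 3 (within the scatter), stayed within the scatter. A step of similar size is therefore expected, a number 2.9 percentage points higher from compound 3 to compound 4 (within the scatter), none beyond the scatter. Compound 4 is expected to give about 32% in this assay, between 20% and 45%.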

Compound 4, a percentage reported as inhibition, at one concentration (the size of the read-out at that concentration, not a potency): 37.9%
Estimate against measurement, compound 4: 5.9 percentage points below; measured number inside the range.
By their numbers in this assay, from the lowest: compounds 3, 1, 2 and 4 (each within the scatter of the next).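

In this assay, the place on a saturated chain carbon bound to an amide-type nitrogen in a ring also accepts 2-(4-fluorophenyl)-1,3-thiazol-4-yl without leaving the scatter: a number 8.8 percentage points higher from compound 3 to compound 4 (within the scatter), a number 2.8 percentage points higher from compound 2 to compound 4 (within the scatter) and a number 3.8 percentage points higher from compound 1 to compound 4 (within the scatter). All four aromatic groups at this place therefore stand together, and this single change cannot separate the fluorine from the altered thiazole attachment. Nothing measured here bears on this result.

Still open, going by these compounds, is what the fluorine does alone, as 2-phenyl-1,3-thiazol-4-yl would show. Also open, on these data alone, is whether an amine or a carboxylic acid at this place would move the number beyond the scatter.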